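Series notes: carbonyl substituent on the piperidine amide

The source may report more compounds than this note shows. Statements on the series, on what has been measured and on what is new or still open speak of the compounds shown alone.

Going by the values given here, compound 2 `Cc1ccccc1C(=O)Nc1ccc(S(=O)(=O)NC2CCN(C(=O)N3CCCC3)CC2)c2ccccc12` holds the lowest of the two numbers so far: in an assay on L1.2 cells for binding affinity to C-C chemokine receptor type 8 (Homo sapiens) (on this read-out lower numbers stand for stronger inhibition and higher numbers for weaker inhibition), compound 2 gives 1.1 nM, while compound 1 `Cc1ccccc1C(=O)Nc1ccc(S(=O)(=O)NC2CCN(C(=O)CCN)CC2)c2ccccc12` gives 11.3 nM. Among the compounds with values here, the one step between them, a 10-fold lower number from compound 1 to compound 2 (1.01 log units; beyond the scatter), accompanies the exchange of an open amine-bearing chain for the ring. Compound 3 `CCN(CC)CCCC(=O)N1CCC(NS(=O)(=O)c2ccc(NC(=O)c3ccccc3C)c3ccccc23)CC1` reverses part of that move: 3-(diethylamino)propyl in place of pyrrolidin-1-yl on a carbonyl carbon. Within the data shown here, only the step from compound 1 bears on it, and it was large, so a return toward an open chain is expected to cost something, though not the whole of it. Compound 3 is expected to give 5 nM, within 1.5 nM to 20 nM, that is a 4.5-fold higher number from compound 2 to compound 3 (0.66 log units; beyond the scatter).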

Compound 3, inhibition constant: 567 nM
Estimate against measurement, compound 3: 110-fold (2.05 log units) below, and the stated range ends below it.
By their numbers in this assay, from the lowest: compound 2; then compound 1; then compound 3.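

At this carbonyl carbon, leaving the ring can cost far more than the earlier pair suggested, with a 520-fold higher number from compound 2 to compound 3 (2.71 log units; beyond the scatter) here. Open chains are not interchangeable either: with a 50-fold higher number from compound 1 to compound 3 (1.70 log units; beyond the scatter) as the step, the number depends on the make-up of the chain and not only on the absence of the ring. Nothing at hand accounts for the size of these steps.

Compound 3 differs from compound 1 in both chain length and the ethyl groups on the nitrogen, so these two changes remain unseparated. A 3-aminopropyl or a 2-(diethylamino)ethyl group on the same carbonyl carbon would divide them.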